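The compounds below may be only part of what the source reports. "The series", "measured", "known", "first", "only" and "open" are said of these compounds alone.

The account follows compound 1 `Cc1cc(C)cc(S(=O)(=O)c2c(C(=O)NCc3cccc(N)c3)[nH]c3ccc(Cl)cc23)c1` toward compound 4 `Cc1cc(C)cc(S(=O)(=O)c2c(C(=O)NC(C)C(=O)NCc3ccco3)[nH]c3ccc(Cl)cc23)c1`. In an ADME assay on MT4 cells (Homo sapiens) for cytotoxicity, read by MTT assay (on this read-out lower numbers stand for higher toxicity in this test and higher numbers for lower toxicity in this test), compound 1 gives > 53400 nM, which is a limit of the assay rather than a number (the limit of > 53400 nM in this assay, at which 1 of the 3 values shown sits). Compound 2 `Cc1cc(C)cc(S(=O)(=O)c2c(C(=O)NCc3ccc4nc(N)[nH]c4c3)[nH]c3ccc(Cl)cc23)c1` gives 5890 nM in this assay, and compound 3 `Cc1cc(C)cc(S(=O)(=O)c2c(C(=O)NC(C)C(=O)NC(C)c3ccccc3)[nH]c3ccc(Cl)cc23)c1` gives 21700 nM. Going by the values given here, the only measured single-change step, an at least 9.0-fold lower number from compound 1 to compound 2 (0.95 log units; beyond the scatter), concerns a different group and does not bear directly on the change at hand, which is 1-(((furan-2-yl)methyl)carbamoyl)ethyl in place of 3-aminobenzyl on an amide-type nitrogen. Compound 3 carries a related chain ending in an amide and sits at 21700 nM, so compound 4 is expected to land near it, with an at least 2.1-fold lower number from compound 1 to compound 4 (0.32 log units; beyond the scatter) estimated as a move toward higher toxicity. Compound 4 is therefore estimated at 25000 nM, in the range 8000 nM to 70000 nM.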

Compound 4, half-maximal cytotoxic concentration: 24200 nM
Beside the measured number, compound 4's estimate is 1.0-fold (0.01 log units) above it; the range from low to high includes it.
By their numbers in this assay, from the lowest: compound 2; then compounds 3 and 4 (each within the scatter of the next). At a limit, above all of these: compound 1.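

Compound 1 holds a limit of the assay, not a number: the limit of > 53400 nM in this assay, at which 1 of the 4 values shown sits. Against that limit, this assay shows an at least 2.2-fold lower number from compound 1 to compound 4 (0.34 log units; beyond the scatter) for the new chain on the amide-type nitrogen, while (furan-2-yl)methyl in place of 1-phenylethyl gives a 1.1-fold higher number from compound 3 to compound 4 (0.05 log units; within the scatter) and leaves compound 3 and compound 4 indistinguishable. The 2-amino-1H-benzimidazol-6-yl group of compound 2 stays apart, with a 4.1-fold higher number from compound 2 to compound 4 (0.61 log units; beyond the scatter) also printed for this position. From the compounds shown here alone, what an amine or a carboxylic acid at the end of this chain, or a longer chain, would give remains open.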